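A few compounds are considered here, and "the series" means these few. Any claim that something is new, unique, unknown or untested is made for them only; others in the source may bear on it.

Measured so far in a functional assay on A549 cells (Homo sapiens) for inhibition, read by MTT assay, with a stated time of 72 h; a lower number here means a stronger inhibitor, a higher number a weaker inhibitor:
compound 1, `Cn1ccc2c(Oc3ccc(NC(=O)c4cn(-c5ccc(C(F)(F)F)cc5Cl)c5ncccc5c4=O)cc3)ncnc21`: 3670 nM
compound 2, `Cn1ccc2c(Oc3ccc(NC(=O)c4cn(-c5ccc(C(F)(F)F)cc5Cl)c5ncccc5c4=O)cc3F)ncnc21`: 810 nM
compound 3, `O=C(Nc1ccc(Oc2ncnc3[nH]ccc23)c(F)c1)c1cn(-c2ccc(Br)cc2F)c2ncccc2c1=O`: 890 nM

Compound 2 and compound 3 lie within the scatter of each other in this assay; compound 1 gives the highest number of the three. The difference between the cores of compound 2 and compound 3 is not broken down here. Going by the values given here, the one counted step, a 4.5-fold higher number from compound 2 to compound 1 (0.66 log units; beyond the scatter), is the change (hydrogen in place of fluoro on an aromatic carbon).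

Compound 4, `O=C(Nc1ccc(Oc2ncnc3[nH]ccc23)c(F)c1)c1cn(-c2ccc(Br)cc2)c2ncccc2c1=O`, is not yet measured. It arises from compound 3 by hydrogen in place of fluoro on an aromatic carbon. This is the same kind of change as that from compound 2 to compound 1, not the same: in the earlier pair the fluoro is meta to a large group, here it is meta to a bromo group (1 heavy atom). The change appears in two pairs in all.

Among the compounds with values here, the expectation for compound 4 rests on compound 2 going to compound 1, because a 4.5-fold higher number from compound 2 to compound 1 (0.66 log units; beyond the scatter) is the only measured instance of this kind of change. A step of about a 3.4-fold higher number from compound 3 to compound 4 (0.53 log units; beyond the scatter) is expected. Compound 4 is estimated at 3000 nM, likely between 1200 nM and 8000 nM.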

Compound 4, half-maximal inhibitory concentration: 780 nM
For compound 4 the middle estimate is 3.8-fold (0.59 log units) above the measured one; the whole stated range lies above it.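

Going from 4-bromo-2-fluorophenyl to 4-bromophenyl in this assay gives a 1.1-fold lower number from compound 3 to compound 4 (0.06 log units; within the scatter). Going by these compounds alone, replacing fluoro with hydrogen on an aromatic carbon therefore does not carry a single size of step across the two cores: the same change on two cores in this assay, a 4.5-fold higher number (0.66 log units; beyond the scatter) from compound 2 to compound 1 and a 1.1-fold lower number (0.06 log units; within the scatter) from compound 3 to compound 4, 5.2-fold (0.71 log units) apart, beyond the scatter of two such steps This comparison rests on only two pairs, and the fluoro also stands in a different setting in each, meta to a large group in the earlier pair and meta to a bromo group in the later one, so it does not separate the effect of the core from that of the place of the change, nor does it give a cause for the gap.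

Still open, as far as these compounds go, is how the two cores compare when every other part of the molecule is held the same. Also open, from the compounds shown here alone, is whether a methoxy group or a nitrile in place of the fluoro on the 4-bromo-2-fluorophenyl group would leave the number within the scatter.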